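The source may hold more compounds than are shown below. What is called first, only, known or untested is meant among the compounds shown, and "the series" means these compounds.

Measured so far:
compound 1 `Cn1ncc(Cl)c1-c1cc(C(=O)N[C@@H]2CN[C@H](CC(=O)O)C[C@H]2c2ccc(Cl)c(Cl)c2)oc1Cl` — 1.94 nM
compound 2 `CNC(=O)C[C@@H]1C[C@@H](c2ccc(F)c(F)c2)[C@H](NC(=O)c2cc(-c3c(Cl)cnn3C)c(Cl)o2)CN1` — 1.37 nM

Both numbers come from an assay for inhibition of RAC-alpha serine/threonine-protein kinase (Homo sapiens), read by HTRF, with a stated time of 1 h; a higher number here means a weaker inhibitor, a lower number a stronger inhibitor. Compound 1 gives the higher of the two, yet compound 2 lies within the usual scatter of it, so the two cannot be ranked. For the measured compounds named here, compound 2 also differs from compound 1 in more than one place, so its value shows only that a compound carrying an amide at that end of the chain also inhibits strongly in this assay . The step followed here leads to compound 3 `Cn1ncc(Cl)c1-c1cc(C(=O)N[C@@H]2CN[C@H](CC(=O)NC3CCC3)C[C@H]2c2ccc(Cl)c(Cl)c2)oc1Cl`, not yet measured. It differs from compound 1 in one place: cyclobutylamino in place of hydroxy on a carbonyl carbon. Going by the values given here, no measured pair shows this exact change. Given that compound 2 holds an amide there and gives 1.37 nM, the expected step is a 1.3-fold higher number from compound 1 to compound 3 (0.11 log units; within the scatter), no larger than the scatter and without a firm direction. Compound 3 is therefore estimated at 2.5 nM, with a range from 0.8 nM to 8 nM.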

Compound 3, half-maximal inhibitory concentration: 7.98 nM
Compound 3: the middle estimate sits 3.2-fold (0.50 log units) below what was measured; low and high end bracket the measured number.
By their numbers in this assay, from the lowest: compounds 2 and 1 (each within the scatter of the next); then compound 3.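

In this assay, putting cyclobutylamino in place of hydroxy on this carbonyl carbon gives a 4.1-fold higher number from compound 1 to compound 3 (0.61 log units; beyond the scatter) as a modest but real step, so this position does respond to the change and the carboxylic acid of compound 1 is the stronger inhibitor of this pair. The position still accepts the larger group, with its four-membered ring, since compound 3 gives 7.98 nM and remains a measurable inhibitor in this assay on the same core. Nothing available explains why the number rises.

Going by these compounds, it remains open whether the step comes from the amide itself or from the cyclobutyl ring. A plain primary amide, a methylamide or a cyclopentylamide on the core of compound 1 would help separate these two possibilities.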